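The source may report more compounds than this note shows. Statements on the series, on what has been measured and on what is new or still open speak of the compounds shown alone.

Of the compounds shown here, two with the same shared core have been measured in a functional assay on MCF7 cells (Homo sapiens) for inhibition, read by sulforhodamine B assay, with a stated time of 48 h; on this read-out higher numbers stand for weaker inhibition and lower numbers for stronger inhibition. Compound 1 `COc1ccc(C(c2ccc(OC(C)CN(C)C)cc2)c2cccc3ccccc23)c(OC)c1OC` gives 13100 nM in this assay. Compound 2 `COc1ccc(/C(=C\c2ccc(F)cc2)c2cccc3ccccc23)c(OC)c1OC` gives 17700 nM in this assay. These two numbers lie within the usual scatter of each other, so neither compound stands apart from the other on what has been measured.

Compound 3 `COc1ccc(/C(=C/c2ccc(F)cc2)c2cccc3ccccc23)c(OC)c1OC` differs from compound 2 only in how one double bond is drawn: the two compounds have the same atoms and bonds and differ only in configuration as drawn: 1 of 1 stereo elements differ; a double bond is drawn Z in compound 2 and E in compound 3. For the measured compounds named here, no measured pair shows what this kind of change does in this assay, so nothing indicates a direction. Going by the values given here, with no guide from measured compounds, the expected step from compound 2 to compound 3 is a 1.2-fold lower number from compound 2 to compound 3 (0.07 log units; within the scatter), not beyond the scatter, though the uncertainty is wide. Compound 3 is therefore expected to give about 15000 nM in this assay, with a likely range from 4000 nM to 50000 nM.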

Compound 3, half-maximal inhibitory concentration: 10500 nM
Compound 3: middle estimate off by 1.4-fold (0.15 log units), on the high side, and the stated range covers the measured number.
By their numbers in this assay, from the lowest: compounds 3, 1 and 2 (each within the scatter of the next).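

For the compounds shown here, this pair is the first measured case in which only the configuration of the double bond changes in this assay, and the step is a 1.7-fold lower number from compound 2 to compound 3 (0.23 log units; within the scatter). For this pair, then, the Z and E forms as drawn cannot be told apart in this assay, so the arrangement around this double bond shows no measurable effect here. The comparison is a clean one because nothing else separates the two structures: the fact that compounds 2 and 3 differ only in the configuration as drawn

The compounds shown leave open whether the two forms would stay this close if the fluorine were replaced, for example by a nitrile or a carboxylic acid. They also leave open what a hydroxyl group in place of one of the methoxy groups would do to either form.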